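The source may report more compounds than this note shows. Statements on the series, on what has been measured and on what is new or still open speak of the compounds shown alone.

Compound 1, `Nc1ccccc1NC(=O)c1ccc(CSC(=S)N2CCc3ccccc32)cc1`, gives 85.4% in a functional assay on A-375 cells (Homo sapiens) for antiproliferative activity, read by CCK-8 assay, with a stated time of 72 h, tested at 8 uM (a higher number here means a stronger effect of the compound at the concentration tested, a lower number a weaker effect), and compound 2, `Nc1ccccc1NC(=O)c1ccc(CSC(=S)N2CCCc3ccccc32)cc1`, gives 81.5%. Among these two numbers compound 2 stands lowest, with compound 1 nearest to it, the step being a number 3.9 percentage points lower from compound 1 to compound 2 (within the scatter). Compound 3, `Nc1ccccc1NC(=O)c1ccc(CSC(=S)N2CCc3cc(Cl)ccc32)cc1`, has not yet been measured. It differs from compound 2 in one place: 5-chloro-2,3-dihydro-1H-indol-1-yl in place of 1,2,3,4-tetrahydroquinolin-1-yl on a thiocarbonyl carbon. Going by the values given here, the only measured step that bears on this is the one from compound 1 to compound 2, which swapped the same two rings in the opposite direction and stayed within the scatter. Among the compounds with values here, the chlorine that enters with compound 3 has no measured counterpart in this set, so nothing points to a direction for it. Compound 3 is therefore expected to move by a number 2.5 percentage points higher from compound 2 to compound 3 (within the scatter), a step not beyond the scatter, and its value in this assay is estimated at 84%, ranging from 72% to 93%.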

Compound 3, a percentage reported as inhibition, at one concentration (the size of the read-out at that concentration, not a potency): 82.3%
Estimate against measurement, compound 3: 1.7 percentage points above; the range from low to high includes it.
By their numbers in this assay, from the lowest: compounds 2, 3 and 1 (each within the scatter of the next).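

In this assay the chlorine now has a measured step of its own, since chloro in place of hydrogen on an aromatic carbon gives a number 3.1 percentage points lower from compound 1 to compound 3 (within the scatter) and so leaves the number unresolved from that of the unsubstituted ring. Changing the ring size and adding the chlorine in one exchange gives a number 0.8 percentage points higher from compound 2 to compound 3 (within the scatter), so the three groups on the thiocarbonyl carbon shown here cannot be told apart at this concentration. No evidence is available that would explain these results.

Going by these compounds, it remains open whether a group of another kind on the thiocarbonyl carbon, such as morpholine or an open-chain diethylamino group, would give a step beyond the scatter. Also open, on these data alone, is whether methoxy or a carboxylic acid in place of the chloro would do so.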